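The source may report more compounds than this note shows. Statements on the series, on what has been measured and on what is new or still open speak of the compounds shown alone.

Compound 1 `CCCCCCOC(=O)CCC(=O)N1CCN(CCCOc2cc3c(Nc4ccc(F)c(Cl)c4)ncnc3cc2OC)CC1` gives 89.3% in a functional assay on A549 cells (Homo sapiens) for cytotoxicity, read by MTT assay, with a stated time of 24 h, tested at 10 uM; a higher number here means a weaker effect of the compound at the concentration tested, a lower number a stronger effect.
Compound 2 `CCCCCCCCOC(=O)CCC(=O)N1CCN(CCCOc2cc3c(Nc4ccc(F)c(Cl)c4)ncnc3cc2OC)CC1` gives 87.3%.
Compound 3 `CCCCCCCCCOC(=O)CCC(=O)N1CCN(CCCOc2cc3c(Nc4ccc(F)c(Cl)c4)ncnc3cc2OC)CC1` gives 90%.

Compound 3 stands alongside the other two rather than apart from them: a number 0.7 percentage points higher from compound 1 to compound 3 (within the scatter) and a number 2.7 percentage points higher from compound 2 to compound 3 (within the scatter), neither beyond the scatter. Compound 4 `CCCCCCCCCCCCOC(=O)CCC(=O)N1CCN(CCCOc2cc3c(Nc4ccc(F)c(Cl)c4)ncnc3cc2OC)CC1` differs from compound 3 by propyl in place of hydrogen on a saturated chain carbon, nine bonds along the chain from an oxygen next to a carbonyl group. Every measured step is a lengthening of this same chain: a number 2 percentage points lower from compound 1 to compound 2 (within the scatter), a number 0.7 percentage points higher from compound 1 to compound 3 (within the scatter) and a number 2.7 percentage points higher from compound 2 to compound 3 (within the scatter), all within the scatter. Adding a further stretch of chain in compound 4 is therefore expected to bring no step beyond the scatter in this assay, in either direction. On that basis compound 4 is estimated at 90%, within 83% to 96%. The expected step is no change at the digits printed from compound 3 to compound 4 (within the scatter).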

Compound 4, a percentage reported as activity, at one concentration (the size of the read-out at that concentration, not a potency): 95.5%
Beside the measured number, compound 4's estimate is 5.5 percentage points below it; the range from low to high includes it.
By their numbers in this assay, from the lowest: compounds 2, 1, 3 and 4 (each within the scatter of the next).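

In this assay, the longest chain shown still does not separate from the shorter ones (a number 5.5 percentage points higher from compound 3 to compound 4 (within the scatter)), (a number 8.2 percentage points higher from compound 2 to compound 4 (within the scatter)) and (a number 6.2 percentage points higher from compound 1 to compound 4 (within the scatter)). So even with hexyl in place of hydrogen, six bonds along the chain from an oxygen next to a carbonyl group, chain length at this position shows no effect on this reading beyond the scatter. Nothing available offers a reason for this flat picture.

On these data alone, whether a still longer chain, or a carboxylic acid or an amine at the end of this chain, would move the reading beyond the scatter stays open.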